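Thiazole to Carboxypyridine: an Expected Loss of Agonist Potency

The source may hold more compounds than are shown below. What is called first, only, known or untested is meant among the compounds shown, and "the series" means these compounds.

Compound 1 `CCC(C)(C)Cc1c[nH]c(CCc2ccc(-c3cnsc3)cc2)n1` gives 44 nM in a functional assay on HEK293 cells for agonist activity at Bombesin receptor subtype-3 (Homo sapiens), read by luminescence and calcium flux, with a stated time of 10 min; a higher number here means that more compound is needed for the effect, a lower number that less compound is needed; compound 2 `CCC(C)(C)Cc1c[nH]c(CCc2ccc(-c3cccc(C#N)n3)cc2)n1` gives 193 nM; compound 3 `CCC(C)(C)Cc1c[nH]c(CCc2ccc(-c3ccns3)cc2)n1` gives 63 nM.

Compound 3 has the second highest number of the three: a 1.4-fold higher number from compound 1 to compound 3 (0.16 log units; within the scatter), while a 3.1-fold lower number from compound 2 to compound 3 (0.49 log units; beyond the scatter). Compound 4 `CCC(C)(C)Cc1c[nH]c(CCc2ccc(-c3cccnc3C(=O)O)cc2)n1` differs from compound 3 in one place: 2-carboxypyridin-3-yl in place of 1,2-thiazol-5-yl on an aromatic carbon. Among the measured compounds shown here, the steps that bear on this are a 4.4-fold higher number from compound 1 to compound 2 (0.64 log units; beyond the scatter) and a 3.1-fold lower number from compound 2 to compound 3 (0.49 log units; beyond the scatter), the only examples of a six-membered ring in this position, and both put that ring at the higher number. For the measured compounds named here, no measured compound carries a carboxylic acid, so that part of the change is untested. On this basis a higher number is expected for compound 4, roughly a 5.6-fold higher number from compound 3 to compound 4 (0.74 log units; beyond the scatter). The estimate for compound 4 is 350 nM, within a range of 90 nM to 2000 nM.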

Compound 4, half-maximal effective concentration: 1260 nM
For compound 4 the middle estimate is 3.6-fold (0.56 log units) below the measured one; the measured number falls inside the stated range.
By their numbers in this assay, from the lowest: compounds 1 and 3 (each within the scatter of the next); then compound 2; then compound 4.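

Placing 2-carboxypyridin-3-yl on this aromatic carbon gives a 20-fold higher number from compound 3 to compound 4 (1.30 log units; beyond the scatter) in this assay and a 29-fold higher number from compound 1 to compound 4 (1.46 log units; beyond the scatter) when set against the other 1,2-thiazole, the largest steps yet seen at this position. It also gives a 6.5-fold higher number from compound 2 to compound 4 (0.81 log units; beyond the scatter) when set against the only other six-membered ring, so a six-membered ring here does not by itself fix the number.

A methyl ester or a primary amide in place of the carboxylic acid would help show how much of the rise belongs to the acid itself. Nothing available explains the rise.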